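Aza-ring exchange on the bicyclic portion of compound 2

A few compounds are considered here, and "the series" means these few. Any claim that something is new, unique, unknown or untested is made for them only; others in the source may bear on it.

Compound 2 `O=C(Nc1ccc(-n2ncc3c(F)cccc32)cc1)Nc1ccc(Cl)c(C(F)(F)F)c1` gives the highest number of the three measured compounds: in a functional assay on LoVo cells (Homo sapiens) for cytotoxicity, read by MTT assay, with a stated time of 72 h (on this read-out lower numbers stand for stronger inhibition and higher numbers for weaker inhibition), compound 2 gives 9800 nM. Compound 1 `O=C(Nc1ccc(-n2ncc3c(C(F)(F)F)cccc32)cc1)Nc1ccc(Cl)c(C(F)(F)F)c1` gives 3000 nM, and compound 3 `CNc1cccc2c1cnn2-c1ccc(NC(=O)Nc2ccc(Cl)c(C(F)(F)F)c2)cc1` gives 6300 nM. The steps reaching compound 2 are a 3.3-fold higher number from compound 1 to compound 2 (0.51 log units; beyond the scatter) and a 1.6-fold lower number from compound 2 to compound 3 (0.19 log units; within the scatter), while a 2.1-fold higher number from compound 1 to compound 3 (0.32 log units; beyond the scatter) completes the set. Compound 4 `O=C(Nc1ccc(-n2ncc3cccnc32)cc1)Nc1ccc(Cl)c(C(F)(F)F)c1` differs from compound 2 by a group of 9 heavy atoms (6 carbon, 3 nitrogen; one five-membered aromatic ring with 2 hetero atoms, one six-membered aromatic ring with 1 hetero atom) in place of a group of 10 heavy atoms (7 carbon, 2 nitrogen, 1 fluorine; one five-membered aromatic ring with 2 hetero atoms, one six-membered aromatic ring of carbon only), on an aromatic carbon. Within the data shown here, none of the measured steps exchanges the six-membered aromatic ring of carbon only for one with a hetero atom; they only vary the group on that ring, and their sizes run from modest to within the scatter. A step of similar or smaller size, without a settled direction, is therefore expected, and compound 4 is estimated at 7000 nM in this assay (range 2500 nM to 20000 nM), an expected 1.4-fold lower number from compound 2 to compound 4 (0.15 log units; within the scatter).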

Compound 4, half-maximal inhibitory concentration: 32000 nM
Estimate against measurement, compound 4: 4.6-fold (0.66 log units) below, outside the stated range (above it).
By their numbers in this assay, from the lowest: compound 1; then compounds 3 and 2 (each within the scatter of the next); then compound 4.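

In this assay, replacing the 4-fluoro-1H-indazol-1-yl group with the group carrying a hetero atom in its six-membered ring gives a 3.3-fold higher number from compound 2 to compound 4 (0.51 log units; beyond the scatter), so changing that ring itself, not only the group on it, moves the number beyond the scatter. The change also removes the fluorine, so this single step combines two differences. Nothing available here explains the step.

The compounds shown leave open how much of the step belongs to the ring nitrogen and how much to the lost fluorine. They also leave open whether a methoxy group on the new ring would lower the number.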